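The compounds below may be only part of what the source reports. "The series", "measured", "known", "first", "only" and "open" are said of these compounds alone.

Compound 1 `O=C(/C=C/c1cccc(Br)n1)Nc1ccc2ncnc(Nc3cccc(Cl)c3)c2c1`: 10700 nM
Compound 2 `O=C(/C=C/c1cccs1)Nc1ccc2ncnc(Nc3cccc(Cl)c3)c2c1`: 10400 nM

In a functional assay on HepG2 cells (Homo sapiens) for antiproliferative activity, read by MTT assay, with a stated time of 48 h (on this read-out higher numbers stand for weaker inhibition and lower numbers for stronger inhibition), compound 2 stands alongside compound 1, the two numbers lying within the usual scatter of each other, as the step of a 1.0-fold lower number from compound 1 to compound 2 (0.01 log units; within the scatter) shows. Compound 3 `O=C(/C=C/c1ccc(Br)s1)Nc1ccc2ncnc(Nc3cccc(Cl)c3)c2c1` differs from compound 2 by bromo in place of hydrogen on an aromatic carbon. Among the measured compounds shown here, no measured step bears directly on adding a bromine to this ring; the only step known, a 1.0-fold lower number from compound 1 to compound 2 (0.01 log units; within the scatter), swaps the whole ring and stays within the scatter, and compound 1 already carries a bromine on its ring without any shift. The step expected is therefore a 1.0-fold lower number from compound 2 to compound 3 (0.02 log units; within the scatter), none beyond the scatter. Compound 3 is estimated at 10000 nM, with a range from 4000 nM to 25000 nM.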

Compound 3, half-maximal inhibitory concentration: 8850 nM
Compound 3: middle estimate off by 1.1-fold (0.05 log units), on the high side; the measured number falls inside the stated range.
By their numbers in this assay, from the lowest: compounds 3, 2 and 1 (each within the scatter of the next).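

Bromo on this carbon next to the ring sulfur, a change of a single atom on the thiophen-2-yl ring, stays within the scatter in this assay (a 1.2-fold lower number from compound 2 to compound 3 (0.07 log units; within the scatter)). The 5-bromothiophen-2-yl group also stays within the scatter of 6-bromopyridin-2-yl (a 1.2-fold lower number from compound 1 to compound 3 (0.08 log units; within the scatter)), so neither change separates these compounds in this read-out. Nothing available gives a reason for this result. The compounds shown leave open whether an amine, a carboxylic acid or a longer chain on this carbon would move the number beyond the scatter.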